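A few compounds are considered here, and "the series" means these few. Any claim that something is new, unique, unknown or untested is made for them only; others in the source may bear on it.

Series notes. Compound 1 `CC(C)n1ncc2c(C(=O)Nc3ccccc3)cccc21` is the anchor of the set; in a functional assay on HepG2 cells (Homo sapiens) for inhibition, read by MTT assay, with a stated time of 72 h (on this read-out higher numbers stand for weaker inhibition and lower numbers for stronger inhibition), compound 1 gives 23700 nM. Compound 2 `CC(C)n1ncc2c(C(=O)Nc3cccnc3)cccc21` is its direct relative. In this assay compound 2 reaches only the limit > 40000 nM. The step of an at least 1.6-fold higher number from compound 1 to compound 2 (0.22 log units; that floor lies within the scatter) is thus open at one end. Compound 3 `CC(C)n1ncc2c(C(=O)NCc3cn(-c4ccc(I)cc4)nn3)cccc21` carries a different group on the amide-type nitrogen. In this assay compound 3 also sits at the limit > 40000 nM. Compound 3 therefore stands on (the limit of > 40000 nM in this assay, at which 2 of the 3 values shown sit), with no number of its own.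

Compound 4 `Cc1ccccc1-n1cc(CNC(=O)c2cccc3c2cnn3C(C)C)nn1` differs from compound 3 by 2-methylphenyl in place of 4-iodophenyl on an aromatic nitrogen. Going by the values given here, no measured step touches this position; the one measured step, an at least 1.6-fold higher number from compound 1 to compound 2 (0.22 log units; that floor lies within the scatter), concerns the amide-type nitrogen and is itself only a bound. The expected step is a step that the limit leaves unreadable from compound 3 to compound 4, which is none beyond the scatter. For compound 4 the estimate in this assay is 45000 nM, between 20000 nM and 100000 nM, and it is expected most likely to return again only a limit.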

Compound 4, half-maximal inhibitory concentration: > 40000 nM
Compound 4 ended at the assay's limit; the forecaster's own chance of this, stated with the estimate: 65%; the middle value is on the limit's open side.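

In this assay compound 3 and compound 4 both stand at a limit and not at a number, so no step between them can be read: the limit of > 40000 nM in this assay, at which 3 of the 4 values shown sit.

The compounds shown leave open how 2-methylphenyl and 4-iodophenyl on the aromatic nitrogen compare, as neither compound has a number of its own.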